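Notes on an aryl exchange in a small lipophilicity series

The source may report more compounds than this note shows. Statements on the series, on what has been measured and on what is new or still open speak of the compounds shown alone.

Measured so far:
compound 1, `CC1=C(C(=O)OCc2cccnc2)C(c2ccco2)C2=C(CCCC2=O)N1`, gives 1.03
compound 2, `CC1=C(C(=O)OCc2ccccn2)C(c2ccco2)C2=C(CCCC2=O)N1`, gives 1.4

For the measured compounds named here, compound 2 stands highest of the two numbers in a physicochemical assay for lipophilicity, measured as octanol-water partition; a higher number here means a more lipophilic compound, a lower number a more polar compound; its only neighbour is compound 1, and the single measured step, a number 0.37 log units higher from compound 1 to compound 2 (beyond the scatter), separates them. Compound 3, `CC1=C(C(=O)OCc2ccccn2)C(c2ccc(O)cc2)C2=C(CCCC2=O)N1`, has not been measured. It differs from compound 2 as follows: 4-hydroxyphenyl in place of furan-2-yl on a saturated ring carbon. Going by the values given here, the one measured step concerns another place in the molecule and does not touch the group exchanged here, so no direct guide to the size or direction of this change exists. One aromatic ring is replaced by another aromatic ring carrying one hydrogen-bond donor and one hydrogen-bond acceptor. Among the compounds with values here, with no precedent, compound 3 is expected to remain close to compound 2, the expected step being a number 0.05 log units higher from compound 2 to compound 3 (within the scatter), probably within the scatter. The estimate for compound 3 is 1.45, with a range from 1 to 1.9.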

Compound 3, partition coefficient: 1.58
Compound 3: the middle estimate sits 0.13 log units below what was measured; low and high end bracket the measured number.
By their numbers in this assay, from the lowest: compound 1; then compounds 2 and 3 (each within the scatter of the next).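

At the saturated ring carbon, 4-hydroxyphenyl in place of furan-2-yl gives, in this assay, a number 0.18 log units higher from compound 2 to compound 3 (within the scatter). For the compounds shown here, this is the first reading at this position, and it shows that exchanging the five-membered aromatic ring with its hetero atom for a six-membered carbon ring carrying a hydrogen-bond donor leaves compound 3 not distinguishable from compound 2 in this measurement. Nothing available accounts for this result.

On these data alone, the exchange alters the ring and adds the hydroxyl group together, so a plain phenyl group would be needed to separate the two, and how an amine or a carboxylic acid on the phenyl ring would read remains open. As far as these compounds go, whether the same result holds with pyridin-3-yl on the saturated chain carbon also remains open.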